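The source may report more compounds than this note shows. Statements on the series, on what has been measured and on what is new or still open speak of the compounds shown alone.

In an assay on HEK293 cells for displacement of a labelled ligand from corticotropin-releasing factor receptor 1 (Homo sapiens) (a higher number here means a weaker inhibitor, a lower number a stronger inhibitor), compound 1 `CCCN(CC)c1cc(C)nc2c(-c3ccc(Cl)cc3Cl)nn(C)c12` gives 4.1 nM and compound 2 `CCCCCN(CCC)c1cc(C)nc2c(-c3ccc(Cl)cc3Cl)nn(C)c12` gives 1.2 nM, the lowest of the two numbers in this assay. Compound 3 `CCCN(Cc1ccc(O)cc1)c1cc(C)nc2c(-c3ccc(Cl)cc3Cl)nn(C)c12` differs from compound 2 by 4-hydroxyphenyl in place of butyl on a saturated chain carbon bound to a nitrogen on an aromatic ring. Going by the values given here, the only measured step, a 3.4-fold lower number from compound 1 to compound 2 (0.53 log units; beyond the scatter), concerns lengthening of a chain and says nothing about an aromatic group entering in place of an alkyl chain. Without direct precedent, the change is expected to leave the number close to that of compound 2 or raise it modestly. Compound 3 is therefore estimated at 3 nM, with a range of 0.8 nM to 12 nM. This corresponds to an expected 2.5-fold higher number from compound 2 to compound 3 (0.40 log units; beyond the scatter).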

Compound 3, inhibition constant: 13 nM
Estimate against measurement, compound 3: 4.3-fold (0.64 log units) below; measured number outside the range, above it.
By their numbers in this assay, from the lowest: compound 2; then compound 1; then compound 3.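

In this assay, the aromatic group at this place, on a saturated chain carbon bound to a nitrogen on an aromatic ring, gives an 11-fold higher number from compound 2 to compound 3 (1.03 log units; beyond the scatter) and, against the shorter chain, a 3.2-fold higher number from compound 1 to compound 3 (0.50 log units; beyond the scatter) as well. Among these three compounds, 4-hydroxybenzyl therefore gives a higher number than either alkyl group it is compared with, so the lower number seen with chain lengthening does not carry over to this group. No available evidence accounts for this rise. Still open, as far as these compounds go, is whether the ring or its hydroxyl drives the change: plain benzyl would separate the two, and a pentyl chain ending in a hydroxyl would test the oxygen without the ring.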